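Aryl swap on the triazole nitrogen of the amino core

The compounds below may be only part of what the source reports. "The series", "measured", "known", "first", "only" and "open" are said of these compounds alone.

Compound 1 `Cc1cc(C)cc(-n2nncc2CN2C(=O)C3(C(C#N)=C(N)Oc4c3c3nc5ccccc5nc3c3ccccc43)c3ccccc32)c1` and compound 2 `Cc1ccc(-n2nncc2CN2C(=O)C3(C(C#N)=C(N)Oc4c3c3nc5ccccc5nc3c3ccccc43)c3ccccc32)cc1Cl` share one core. In a functional assay on A549 cells (Homo sapiens) for antiproliferative activity, read by MTT assay, with a stated time of 48 h (a higher number here means a weaker inhibitor, a lower number a stronger inhibitor), compound 1 gives > 50000 nM, a limit of the assay rather than a number. In this assay compound 2 likewise gives > 50000 nM, also a limit. The step that the two limits leave unreadable from compound 1 to compound 2 therefore cannot be sized. Going by the values given here, compound 3 `Cc1cccc(-n2nncc2CN2C(=O)C3(C(C#N)=C(N)Oc4c(N)cc5nc6ccccc6nc5c43)c3ccccc32)c1` carries a different core; in this assay compound 3 gives 12300 nM, the only number among the three values. The other two values are accounted for in the limit of > 50000 nM in this assay, at which 2 of the 3 values shown sit.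

Compound 4 `COc1ccccc1-n1nncc1CN1C(=O)C2(C(C#N)=C(N)Oc3c(N)cc4nc5ccccc5nc4c32)c2ccccc21` differs from compound 3 as follows: 2-methoxyphenyl in place of 3-methylphenyl on an aromatic nitrogen.

Among the compounds with values here, no readable measured step bears on this change; the single step from compound 1 to compound 2 is unreadable and sits on a different core. Nothing therefore points in either direction, and the expected step of a 1.1-fold higher number from compound 3 to compound 4 (0.06 log units; within the scatter) is within the usual scatter. Compound 4 is estimated at 14000 nM, with a range from 4000 nM to 50000 nM.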

Compound 4, half-maximal inhibitory concentration: 37500 nM
Beside the measured number, compound 4's estimate is 2.7-fold (0.43 log units) below it, within the range that was stated.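

Exchange of 3-methylphenyl for 2-methoxyphenyl on the aromatic nitrogen gives the first readable step at this position: a 3.0-fold higher number from compound 3 to compound 4 (0.48 log units; beyond the scatter) in this assay. On the core of compound 3, the number therefore responds to the aryl group, and the entering group counts one hydrogen-bond acceptor where the leaving group counts none. The aryl pair on the core of compound 1 could not show this, since both of its values are limits of the assay and not numbers: the limit of > 50000 nM in this assay, at which 2 of the 4 values shown sit.

A single readable step does not separate the methoxy group itself from the place where it sits on the phenyl ring. From the compounds shown here alone, how an aminophenyl or a carboxyphenyl group on the same nitrogen would read on the core of compound 3 remains open.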